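Swapping the Amine Arm for an Oxime Ether

The compounds below may be only part of what the source reports. "The series", "measured", "known", "first", "only" and "open" are said of these compounds alone.

Compound 1 `CC(=O)OC/C1=C/C[C@](C)(CCC=C(C)C)/C=C/[C@@H](OC(=O)C=C(C)C)[C@](C)(OC(C)=O)/C=C/C1=O` gives 3990 nM in a functional assay on MCF7 cells (Homo sapiens) for antiproliferative activity, read by MTT assay, with a stated time of 48 h; a lower number here means a stronger inhibitor, a higher number a weaker inhibitor.
Compound 2 `CCN(CC)C/C1=C/C[C@](C)(CCC=C(C)C)/C=C/[C@@H](OC(=O)C=C(C)C)[C@](C)(O)/C=C/C1=O` gives 130 nM in this assay.
Compound 3 `CC(C)=CCC[C@]1(C)/C=C/[C@@H](OC(=O)C=C(C)C)[C@](C)(O)/C=C/[C@H](O)/C(CO)=C\C1` gives 33000 nM in this assay.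

Compound 2 has the lowest number of the three, and both other compounds sit beyond the usual scatter, compound 1 nearer and compound 3 furthest away. Compound 4 `CO/N=C/C1=C/C[C@](C)(CCC=C(C)C)/C=C/[C@@H](OC(=O)C=C(C)C)[C@](C)(O)/C=C/C1=O` is the next step from compound 2: a group of 4 heavy atoms (2 carbon, 1 nitrogen, 1 oxygen; no ring) in place of a group of 6 heavy atoms (5 carbon, 1 nitrogen; no ring), on a double-bonded ring carbon. Among the compounds with values here, no pair of measured compounds shows this exact change, so the direction must be judged from the three numbers alone. Within the data shown here, since compound 2, the only compound carrying the (diethylamino)methyl group, gives 130 nM while compound 1 and compound 3 both give far higher numbers, the number is expected to rise from compound 2 to compound 4, by a 12-fold higher number from compound 2 to compound 4 (1.06 log units; beyond the scatter), a step beyond the scatter. Compound 4 is estimated at 1500 nM, with a range from 300 nM to 8000 nM.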

Compound 4, half-maximal inhibitory concentration: 2510 nM
Compound 4: the middle estimate sits 1.7-fold (0.22 log units) below what was measured; the measured number falls inside the stated range.
By their numbers in this assay, from the lowest: compound 2; then compounds 4 and 1 (each within the scatter of the next); then compound 3.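

In this assay, replacing the (diethylamino)methyl group with the oxime ether on this double-bonded ring carbon gives a 19-fold higher number from compound 2 to compound 4 (1.29 log units; beyond the scatter). Within the data shown here, this is the first comparison in which only this one place changes, so it shows that the number is sensitive to the group held on this carbon while the rest of the core stays the same. Nothing measured here explains the size of this step.

On these data alone, whether another amine, such as a (dimethylamino)methyl or piperidinylmethyl group, would keep the number as low as compound 2 remains open. So does the effect of a longer chain on the oxime ether oxygen.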